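This account rests on a few compounds, and the source may have more. Where it says the series, first, only, none or still open, it means among the compounds named here.

Compound 1 `O=c1cc(-n2cc(COc3ccccc3)nn2)c2cc(Br)ccc2o1`: 12300 nM
Compound 2 `O=c1cc(-n2cc(COc3ccnc4ccc(Br)cc34)nn2)c2cc(Br)ccc2o1`: 13300 nM

Of the compounds shown here, two have been measured in a functional assay on A549 cells (Homo sapiens) for antiproliferative activity, read by MTT assay, with a stated time of 48 h; on this read-out lower numbers stand for stronger inhibition and higher numbers for weaker inhibition. Compound 1 gives 12300 nM, and compound 2, which carries a larger bicyclic ether in place of the plain phenoxy group, gives 13300 nM. The two numbers lie within the scatter of each other, so the data do not separate the two compounds; both sit in the weak range of this assay.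

Compound 3 `O=c1cc(-n2cc(COc3ccccc3O)nn2)c2cc(Br)ccc2o1` has not been measured yet. It differs from compound 1 in one place: hydroxy in place of hydrogen on an aromatic carbon. For the measured compounds named here, no measured pair shows what this kind of change does on the shared core, so the expectation rests on compound 1 alone. A single hydroxy group is a modest addition, and the expected step from compound 1 to compound 3, a 1.0-fold lower number from compound 1 to compound 3 (0.01 log units; within the scatter), is none beyond the scatter. Compound 3 is therefore expected to give about 12000 nM, within a range from 5000 nM to 30000 nM.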

Compound 3, half-maximal inhibitory concentration: 7940 nM
For compound 3 the middle estimate is 1.5-fold (0.18 log units) above the measured one, within the range that was stated.
By their numbers in this assay, from the lowest: compounds 3, 1 and 2 (each within the scatter of the next).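

For the compounds shown here, changing phenoxy to 2-hydroxyphenoxy gives the first reading of a single change on the shared core: in this assay the step is a 1.5-fold lower number from compound 1 to compound 3 (0.19 log units; within the scatter). Hydroxy can therefore stand at this place, ortho to a large group, without a shift that this assay can separate from the ordinary spread of repeated measurements, and a real gain or loss of a small size cannot be told from that spread. Nothing measured here bears on what lies behind this result.

The compounds shown leave open whether a methoxy group or an amine at the same place, or a hydroxy group elsewhere on the phenoxy ring, would move the number beyond the scatter. They also leave open whether hydroxy would give a similar step on the larger bicyclic ether of compound 2.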